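Shortening the hexyloxy chain of compound 2 to methoxy

This account rests on a few compounds, and the source may have more. Where it says the series, first, only, none or still open, it means among the compounds named here.

In a functional assay on MCF7 cells (Homo sapiens) for inhibition, read by colorimetric assay and MTT assay, with a stated time of 72 h (a lower number here means a stronger inhibitor, a higher number a weaker inhibitor), the measured compounds give these values:
- compound 1 `C=CCCCCOc1ccc(C)cc1-c1cnc(OCCC=C)n1C` gives 53000 nM
- compound 2 `CCCCCCOc1ncc(-c2ccccc2OC)n1C` gives 27000 nM
- compound 3 `COc1ccccc1-c1cnc(OCC(F)(F)C(F)(F)C(F)(F)C(F)(F)C(F)(F)F)n1C` gives 63000 nM

Compound 2 sits at the low end of these three numbers. Compound 2 and compound 1 lie within the scatter of each other, while compound 3 lies beyond the scatter of compound 2.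

Next in line is compound 4 `COc1ccccc1-c1cnc(OC)n1C`, which has not yet been measured. The change from compound 2 is hydrogen in place of pentyl on a saturated chain carbon bound to an oxygen on an aromatic ring, so hexyloxy becomes methoxy. Among the measured compounds shown here, no measured pair differs in one place, so the data hold no direct step for this change. Each measured compound carries a chain longer than methyl there, and nothing yet shows how the short group behaves. The estimated step of a 3.0-fold higher number from compound 2 to compound 4 (0.47 log units; beyond the scatter) points to a higher number, a weaker inhibitor, modestly beyond the scatter. Compound 4 is estimated at 80000 nM (expected range 30000 nM to 200000 nM).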

Compound 4, half-maximal inhibitory concentration: > 100000 nM
Compound 4 ended at the assay's limit; the forecaster's own chance of this, stated with the estimate: 30%; middle value at least 1.2-fold (0.09 log units) away from the limit.
By their numbers in this assay, from the lowest: compounds 2, 1 and 3 (each within the scatter of the next, the first and the last beyond it). At a limit, above all of these: compound 4.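

Compound 4, with methoxy in place of hexyloxy, gives > 100000 nM in this assay, which is a limit of the assay and not a number. Against compound 2, this change is an at least 3.7-fold higher number from compound 2 to compound 4 (0.56 log units; beyond the scatter), so on the shared core the hexyl-to-methyl change at this place gives a weaker inhibitor, the first direct evidence that the chain length here matters in this assay. The size of the step is only a lower bound: the limit of > 100000 nM in this assay, at which 1 of the 4 values shown sits.

As far as these compounds go, how the value moves between hexyloxy and methoxy remains open, and an ethoxy or butoxy group at this place would bear on that. Also open, from the compounds shown here alone, is whether an octyloxy chain, or a hexyloxy chain ending in an amine, would give a lower number than compound 2.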